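From 4-bromobenzyl to 3-nitrobenzyl in a level series

The source may hold more compounds than are shown below. What is called first, only, known or untested is meant among the compounds shown, and "the series" means these compounds.

- Compound 1 `Cc1ccc(CN2CCC(CCNC(=O)/C=C/c3cc(C(C)(C)C)c(O)c(C(C)(C)C)c3)CC2)cc1` gives 60400 nM
- Compound 2 `CC(C)(C)c1cc(/C=C/C(=O)NCCC2CCN(Cc3cccc(F)c3)CC2)cc(C(C)(C)C)c1O` gives 55200 nM
- Compound 3 `CC(C)(C)c1cc(/C=C/C(=O)NCCC2CCN(Cc3ccc(Br)cc3)CC2)cc(C(C)(C)C)c1O` gives 85600 nM

These numbers come from a functional assay, read by spectrophotometry, with a stated time of 30 min (a higher number here means a weaker inhibitor, a lower number a stronger inhibitor), and the three compounds differ only in the group on a saturated chain carbon bound to an amine nitrogen in a ring. Compound 3, which carries 4-bromophenyl there, stands level with the other two, as the steps (a 1.4-fold higher number from compound 1 to compound 3 (0.15 log units; within the scatter)) and (a 1.6-fold higher number from compound 2 to compound 3 (0.19 log units; within the scatter)) show. The remaining step (a 1.1-fold lower number from compound 1 to compound 2 (0.04 log units; within the scatter)) is just as small.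

Not yet measured is compound 4 `CC(C)(C)c1cc(/C=C/C(=O)NCCC2CCN(Cc3cccc([N+](=O)[O-])c3)CC2)cc(C(C)(C)C)c1O` with 3-nitrophenyl in place of 4-bromophenyl at that same place (3-nitrophenyl in place of 4-bromophenyl on a saturated chain carbon bound to an amine nitrogen in a ring). Going by the values given here, no measured compound carries 3-nitrophenyl, which leaves the real size of this step open. Still, all three measured swaps at this place stayed within the scatter, so no step beyond the scatter is expected in this assay and neither direction is favoured. The estimate, set among the three measured values, means an expected step (a 1.3-fold lower number from compound 3 to compound 4 (0.12 log units; within the scatter)) and nothing larger. Compound 4 is expected at 65000 nM with an estimated range from 35000 nM to 120000 nM as its upper end.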

Compound 4, half-maximal inhibitory concentration: 78100 nM
Beside the measured number, compound 4's estimate is 1.2-fold (0.08 log units) below it, and the stated range covers the measured number.
By their numbers in this assay, from the lowest: compounds 2, 1, 4 and 3 (each within the scatter of the next).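

Among the four compounds, 3-nitrophenyl is the only group at this place with a double bond outside the aromatic ring and with hydrogen-bond acceptors, 2 of them, and it has 9 heavy atoms against the 7 of 4-bromophenyl, yet in this assay the swap stays within the scatter (a 1.1-fold lower number from compound 3 to compound 4 (0.04 log units; within the scatter)). The comparisons with the other two compounds also stay within the scatter (a 1.4-fold higher number from compound 2 to compound 4 (0.15 log units; within the scatter)) and (a 1.3-fold higher number from compound 1 to compound 4 (0.11 log units; within the scatter)), so a much wider change in the atoms on this phenyl ring has still not separated any of the four compounds. Nothing available here explains why these different groups give level numbers.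

From the compounds shown here alone, all four compounds keep a benzyl group on the amine nitrogen in the ring, so it remains open whether the number would move beyond the scatter with a carboxylic acid or an amine on the phenyl ring, with a longer chain in place of the benzyl carbon, or with a plain methyl in place of the whole benzyl group. These compounds also leave open whether a change elsewhere on the shared core would matter more than any change at this place.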